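The source may report more compounds than this note shows. Statements on the series, on what has been measured and on what is new or still open speak of the compounds shown alone.

This series shares one core: a piperidine whose nitrogen carries a methylene linked to a five-membered aromatic ring, while the piperidine carbon bears a ketone to a second aromatic group. The study measured an ADME assay on HEK293 cells (Homo sapiens) for cytotoxicity, read by MTT assay, with a stated time of 36 h (a lower number here means a stronger inhibitor, a higher number a weaker inhibitor), on three of them.

Compound 3 `O=C(c1ccc2c(c1)CCCC2)C1CCN(Cc2coc(-c3ccc(F)cc3)n2)CC1` gives > 150 ug/mL in this assay, and that figure is a limit of the assay rather than a number. Compound 1 `O=C(c1ccc2c(c1)OCCO2)C1CCN(Cc2coc(-c3ccoc3)n2)CC1` likewise gives > 150 ug/mL in this assay, again a limit. For compound 2 `O=C(c1ccc2c(c1)OCCO2)C1CCN(Cc2csc(-c3ccc(Cl)cc3)n2)CC1` this assay reports "not determined" (no result reported). So compound 3 stands where the other measured value stands, at the limit of > 150 ug/mL in this assay, at which 2 of the 3 values shown sit, and no compound here separates from another.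

Compound 4 `O=C(c1ccccc1)C1CCN(Cc2coc(-c3ccc(F)cc3)n2)CC1` differs from compound 3 in one place: phenyl in place of 1,2,3,4-tetrahydronaphthalen-6-yl on a carbonyl carbon. Among the compounds with values here, no comparable step between measured compounds exists, so the expectation for the step from compound 3 to compound 4, a number no higher from compound 3 to compound 4 (the limit leaves the size open), is that it stays within the scatter of this assay. Compound 4 is therefore expected to give about 150 ug/mL in this assay, with a range from 75 ug/mL to 300 ug/mL, most likely reported as a limit once more.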

Compound 4, half-maximal inhibitory concentration: > 150 ug/mL
Compound 4 ended at the assay's limit; the forecaster's own chance of this, stated with the estimate: 80%; the middle value sits exactly at the limit.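

Compound 3 and compound 4 both end at a limit rather than a number, so no step can be read between them: the limit of > 150 ug/mL in this assay, at which 3 of the 4 values shown sit.

The compounds shown leave open whether phenyl or 1,2,3,4-tetrahydronaphthalen-6-yl on the carbonyl carbon makes any difference in this assay.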